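The source may hold more compounds than are shown below. What is called first, only, known or untested is meant among the compounds shown, and "the series" means these compounds.

The study looks at a small series of indole ketones tested in an in vitro assay on P815B cells for inhibition of Indoleamine 2,3-dioxygenase 1 (Mus musculus), tested at 20 uM; a lower number here means less inhibition, a higher number more inhibition at the concentration tested (going by the name of the read-out). Compound 1, `O=C(Cc1cccnc1)c1cc2c(F)cccc2[nH]1`, in this assay gives 12%. Compound 2, `O=C(Cc1cccnc1)c1cc2cc(-c3ccccc3)ccc2[nH]1`, in this assay is reported as "not active" (no number reported), with no number attached to it. Compound 3, `O=C(Cc1cnccn1)c1cc2ccccc2[nH]1`, in this assay is likewise reported as "not active" (no number reported), again without a number. Compound 2 therefore stands with no single value to its name; of the three measured compounds only compound 1 has a figure, and that figure is low.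

Compound 4, `O=C(Cc1cccnc1)c1cc2cc(OC(F)(F)F)ccc2[nH]1`, is the compound still to be measured. The change from compound 2 to compound 4 is this: trifluoromethoxy in place of phenyl on an aromatic carbon. Going by the values given here, no step between two measured compounds has been worked out, so the data say nothing about how much such a swap moves inhibition. It is expected that the step in this assay will be small and within the usual scatter rather than beyond it, with no direction that can be claimed, because compound 2 was reported as "not active" (no number reported) and compound 1 gave only 12%. The inhibition of compound 4 in this assay is estimated at 10%, with a range from 0% to 25%.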

Compound 4, a percentage reported as inhibition, at one concentration (the size of the read-out at that concentration, not a potency): 12%
For compound 4 the middle estimate is 2 percentage points below the measured one; measured number inside the range.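

In this assay, going by these compounds alone, compound 4 gives 12% while compound 2 is reported as "not active" (no number reported) and carries no number, so no step between compound 2 and compound 4 can be read. The compounds shown leave open how far trifluoromethoxy in place of phenyl moves inhibition. Nothing shown bears on the reason for this result.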